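This account rests on a few compounds, and the source may have more. Where it says the series, first, only, none or still open, it means among the compounds named here.

Measured in a functional assay (trachea) with Cavia porcellus as the target; on this read-out higher numbers stand for weaker inhibition and lower numbers for stronger inhibition:
Compound 1 `Cn1nc(-c2cccnc2)c2ccccc2c1=O`: 11500 nM
Compound 2 `O=c1c2ccccc2c(-c2cccnc2)nn1Cc1ccccc1`: 2450 nM
Compound 3 `COCCn1nc(-c2cccnc2)c2ccccc2c1=O`: 9330 nM

Two steps fix the place of compound 3 among these numbers. First, a 1.2-fold lower number from compound 1 to compound 3 (0.09 log units; within the scatter), so those two cannot be told apart. Second, a 3.8-fold higher number from compound 2 to compound 3 (0.58 log units; beyond the scatter), which leaves compound 2 clearly the lowest of the three.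

The next compound is compound 4 `CCOC(=O)CCCn1nc(-c2cccnc2)c2ccccc2c1=O`, still to be measured. The change is (ethoxycarbonyl)methyl in place of methoxy on a saturated chain carbon, two bonds along the chain from an aromatic nitrogen. Cut one bond further out, the same difference reads 2-methoxyethyl to 3-(ethoxycarbonyl)propyl.

Going by the values given here, no measured compound carries an ester, so the evidence is indirect and comes only from changes on this same chain. The methoxymethyl change did little: a 1.2-fold lower number from compound 1 to compound 3 (0.09 log units; within the scatter). The one clear gain came with phenyl: a 4.7-fold lower number from compound 1 to compound 2 (0.67 log units; beyond the scatter). Since compound 4 keeps a saturated chain and gains no ring, the methoxymethyl step looks the closer guide, with the phenyl step as a rough outer bound on any fall. A small move towards lower numbers is therefore expected in this assay, probably not beyond the scatter. The estimated change is a 1.6-fold lower number from compound 3 to compound 4 (0.19 log units; within the scatter). For compound 4 the expected value is 6000 nM, with an estimated range of 2000 nM to 15000 nM.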

Compound 4, half-maximal inhibitory concentration: 10000 nM
For compound 4 the middle estimate is 1.7-fold (0.22 log units) below the measured one; the range from low to high includes it.
By their numbers in this assay, from the lowest: compound 2; then compounds 3, 4 and 1 (each within the scatter of the next).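

In this assay, the ester shows that a much larger saturated side chain does not by itself change the reading: the swap of methoxy for (ethoxycarbonyl)methyl gives a 1.1-fold higher number from compound 3 to compound 4 (0.03 log units; within the scatter), and the comparison with the unextended compound gives a 1.2-fold lower number from compound 1 to compound 4 (0.06 log units; within the scatter). The separation from the phenyl compound holds, at a 4.1-fold higher number from compound 2 to compound 4 (0.61 log units; beyond the scatter), so among these four compounds the chains ending in hydrogen, methoxy and the ethyl ester cannot be told apart, and only compound 2 stands clear of the others. Nothing measured here accounts for the ester chain reading like the two smaller groups, or for the place of compound 2.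

As far as these compounds go, it remains open what a carboxylic acid in place of the ethyl ester, or an amine at the end of this chain, would do at this position. From the compounds shown here alone, it is also open whether the lower number of compound 2 belongs to the aromatic ring as such, a question that a cyclohexyl group or a 2-phenylethyl group at the same place would help to settle.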